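This account rests on a few compounds, and the source may have more. Where it says the series, first, only, none or still open, it means among the compounds named here.

Measured compounds:
Compound 1 `COc1cc(C)cc(-c2c(-c3ccnc(-c4ccc(C(C)=O)cc4)c3)cnn2CC#N)c1` gives 92% in a functional assay on MDA-MB-468 cells (Homo sapiens) for cytotoxicity, read by sulforhodamine B assay, with a stated time of 48 h, tested at 0.001 uM; on this read-out higher numbers stand for a weaker effect at the one concentration tested and lower numbers for a stronger effect.
Compound 2 `Cc1cc(O)cc(-c2nn(CC#N)cc2-c2ccnc(-c3ccc(Oc4ccccc4)cc3)c2)c1` gives 91% in this assay.

Of the compounds shown here, two have been measured so far. In this assay compound 2 gives 91%, and in the same assay compound 1 gives 92%; the two numbers lie within the usual scatter of each other, so nothing separates them. Both sit at a level that means only a weak effect at the single concentration tested.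

Compound 3 `Cc1cc(O)cc(-c2nn(CC#N)cc2-c2ccnc(-c3ccc(N(C)C)cc3)c2)c1` has not yet been measured. It differs from compound 2 in one place: dimethylamino in place of phenoxy on an aromatic carbon. Among the measured compounds shown here, no step between measured compounds is available to show what such a change does in this assay, so the expectation rests on compound 2 alone. The step from compound 2 to compound 3 is expected to be a number 1 percentage points lower from compound 2 to compound 3 (within the scatter), which is no change beyond the scatter. Compound 3 is therefore estimated at 90% in this assay, with a range from 78% to 100%.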

Compound 3, a percentage reported as activity, at one concentration (the size of the read-out at that concentration, not a potency): 98%
Compound 3: middle estimate off by 8 percentage points, on the low side; low and high end bracket the measured number.
By their numbers in this assay, from the lowest: compounds 2, 1 and 3 (each within the scatter of the next).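

The exchange of phenoxy for dimethylamino on an aromatic carbon, para to a large group, comes to a number 7 percentage points higher from compound 2 to compound 3 (within the scatter) in this assay. This first step at this position shows that replacing a group of 7 heavy atoms and one aromatic ring with a ringless group of 3 heavy atoms does not move the read-out beyond the scatter at the one concentration tested. Nothing available ties this result to any property of either group.

The compounds shown leave open whether any other group at this position can give a clearly stronger effect in this assay. A primary amine, a carboxylic acid or a morpholine ring in this place could answer that, as could the same groups tested at other concentrations.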